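The source may hold more compounds than are shown below. What is called first, only, known or untested is meant among the compounds shown, and "the series" means these compounds.

Measured compounds:
compound 1 `Cc1ccccc1-n1cc(-c2ccccc2NS(=O)(=O)c2c[nH]c(=O)[nH]c2=O)nn1` — 19900 nM
compound 2 `Cc1cccc(-n2cc(-c3ccccc3NS(=O)(=O)c3c[nH]c(=O)[nH]c3=O)nn2)c1` — 23700 nM
compound 3 `O=c1[nH]cc(S(=O)(=O)Nc2ccccc2-c2cn(-c3cccc(F)c3)nn2)c(=O)[nH]1` — "not toxic" (no number reported)

In an ADME assay on GES1 cells (Homo sapiens) for cytotoxicity, read by MTT assay, with a stated time of 24 h (on this read-out higher numbers stand for lower toxicity in this test and lower numbers for higher toxicity in this test), compound 2 gives 23700 nM, the highest of the two numbers reported. Its nearest neighbour is compound 1, and the step of a 1.2-fold higher number from compound 1 to compound 2 (0.08 log units; within the scatter) moves a methyl group around the same ring and stays within the scatter. Compound 3 carries a 3-fluorophenyl and is recorded in this assay only as "not toxic" (no number reported), with no number attached.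

Compound 4 `O=c1[nH]cc(S(=O)(=O)Nc2ccccc2-c2cn(-c3cccc(Cl)c3)nn2)c(=O)[nH]1` is the next compound. It differs from compound 2 by chloro in place of methyl on an aromatic carbon. Among the measured steps, only the one from compound 1 to compound 2 bears on it, and that step, a shuffle of the methyl, lay within the scatter. Among the measured compounds shown here, no measured step exchanges a methyl for a chloro, so there is no direct precedent. The expectation is therefore a change of a 1.1-fold lower number from compound 2 to compound 4 (0.03 log units; within the scatter), that is, nothing beyond the scatter. Compound 4 is expected to give 22000 nM, with a range from 8000 nM to 60000 nM in this assay.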

Compound 4, half-maximal cytotoxic concentration: > 100000 nM
Compound 4 ended at the assay's limit; the forecaster's own chance of this, stated with the estimate: 25%; at least 4.5-fold (0.65 log units) between middle value and limit.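

Compound 4 gives > 100000 nM in this assay, which is a limit of the assay and not a number. Chloro in place of methyl on the aromatic carbon gives an at least 4.2-fold higher number from compound 2 to compound 4 (0.62 log units; beyond the scatter), and the exchange of 2-methylphenyl for 3-chlorophenyl gives an at least 5.0-fold higher number from compound 1 to compound 4 (0.70 log units; beyond the scatter). Moving the methyl had given only a 1.2-fold higher number from compound 1 to compound 2 (0.08 log units; within the scatter), so this result is the first to show that the read-out can respond clearly to a change on this ring, towards lower toxicity in this test.

The limit leaves the true size of both new steps unknown, and the steps involving compound 3, with its 3-fluorophenyl, cannot be read. Going by these compounds, whether a methoxy group or an amine on the same aromatic carbon would follow chloro or methyl remains open.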